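Swapping the aryl group on the triazole of compound 1

The source may hold more compounds than are shown below. What is called first, only, known or untested is meant among the compounds shown, and "the series" means these compounds.

Compound 1 `C=CCc1ccc(OCc2cn(-c3ccccc3Cl)nn2)c(O)c1` is the lowest of the three measured compounds: in a functional assay on HL-60 cells (Homo sapiens) for inhibition, read by MTT assay, with a stated time of 72 h, tested at 30 uM (on this read-out lower numbers stand for less inhibition of growth and higher numbers for more inhibition of growth at the one concentration tested), compound 1 gives 38.7%. Compound 2 `C=CCc1cc(O)c(O)c(CN2CCC(Cc3ccccc3)CC2)c1` gives 90.6% and compound 3 `C=CCc1cc(O)c(O)c(CN2CCC(C)CC2)c1` gives 91.1%; both stand beyond the scatter above compound 1, while the step of a number 0.5 percentage points higher from compound 2 to compound 3 (within the scatter) lies within the scatter. Compound 4 `C=CCc1ccc(OCc2cn(-c3ccc(OC)cc3)nn2)c(O)c1` differs from compound 1 in one place: 4-methoxyphenyl in place of 2-chlorophenyl on an aromatic nitrogen. Among the compounds with values here, no measured step touches the group on the aromatic nitrogen; the only measured step, between compound 2 and compound 3, concerns a different part of a different core and was within the scatter. No step beyond the scatter is therefore expected, a number 0.3 percentage points higher from compound 1 to compound 4 (within the scatter). Compound 4 is estimated at 39%, expected to fall between 20% and 60%.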

Compound 4, percent growth inhibition at one concentration: 21.3%
For compound 4 the middle estimate is 17.7 percentage points above the measured one; the measured number falls inside the stated range.
By their numbers in this assay, from the lowest: compound 4; then compound 1; then compounds 2 and 3 (each within the scatter of the next).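

Exchanging the aryl group on the aromatic nitrogen does move the result in this assay: 4-methoxyphenyl in place of 2-chlorophenyl gives a number 17.4 percentage points lower from compound 1 to compound 4 (beyond the scatter). This is the first step shown at this position, and it shows that the read-out responds to the group placed here. Nothing available explains the drop in growth inhibition.

This swap changes both the substituent and where it sits on the phenyl ring, and the compounds shown do not separate the two. From the compounds shown here alone, how 4-chlorophenyl, 2-methoxyphenyl or plain phenyl would compare remains open.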